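Iodo for fluoro on the phenoxy ring of a coumarin series

The source may hold more compounds than are shown below. What is called first, only, known or untested is meant among the compounds shown, and "the series" means these compounds.

Compound 2 `Cc1nn(C)c(Oc2ccc(F)cc2)c1/C=N\CCCCCCOc1cc2oc(=O)cc(C)c2cc1Cl` and compound 1 `Cc1nn(C)c(Oc2ccc(Cl)cc2)c1/C=N\CCCCCOc1cc2oc(=O)cc(C)c2cc1Cl` share one core and differ in the halogen on the phenoxy ring and in the length of the linking chain. In a functional assay on HepG2 cells (Homo sapiens) for antiproliferative activity, read by MTT assay, with a stated time of 72 h (a lower number here means a stronger inhibitor, a higher number a weaker inhibitor), compound 2 gives 12500 nM, and compound 1 gives 15300 nM; the two numbers lie within the usual scatter of each other. Compound 3 `Cc1nn(C)c(Oc2ccc(I)cc2)c1/C=N\CCCCCCOc1cc2oc(=O)cc(C)c2cc1Cl` carries the change (iodo in place of fluoro on an aromatic carbon). Among the measured compounds shown here, no measured pair shows this change, so its effect is unknown, and a small step is expected, a 1.4-fold lower number from compound 2 to compound 3 (0.14 log units; within the scatter), leaning toward a lower number. Compound 3 is estimated at 9000 nM, within 4000 nM to 25000 nM.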

Compound 3, half-maximal inhibitory concentration: 14200 nM
Beside the measured number, compound 3's estimate is 1.6-fold (0.20 log units) below it, within the range that was stated.
By their numbers in this assay, from the lowest: compounds 2, 3 and 1 (each within the scatter of the next).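

In this assay, iodo in place of fluoro on the phenoxy ring gives a 1.1-fold higher number from compound 2 to compound 3 (0.06 log units; within the scatter), so this single exchange does not separate the two halogens at this position. Compounds 1 and 2 could not show this, as they differ in both the halogen and the linking chain. No measurement here offers an explanation for the result. As far as these compounds go, whether an amine or a carboxylic acid at this position would behave like the halogens remains open. So does the effect of a longer chain with the phenoxy ring held constant.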